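The source may report more compounds than this note shows. Statements on the series, on what has been measured and on what is new or still open speak of the compounds shown alone.

In a physicochemical assay for solubility (on this read-out lower numbers stand for lower solubility and higher numbers for higher solubility), compound 1 `CNC(=O)c1cc(C(=O)N[C@H]2[C@@H]3COC[C@@H]32)cc2c1OC[C@H]2c1ccccc1` gives >= 165 ug/mL, which is a limit and not a number. Compound 2 `CNC(=O)c1cc(C(=O)N[C@H]2[C@@H]3C[C@@H](O)C[C@@H]32)cc2c1OC[C@H]2c1ccccc1` gives >= 124 ug/mL, also a limit. Compound 3 `CNC(=O)c1cc(C(=O)NCCC[C@H]2OC[C@H](N)CO2)cc2c1OC[C@H]2c1ccccc1` gives >= 153 ug/mL, again a limit. Compound 4 `CNC(=O)c1cc(C(=O)N[C@H]2[C@@H]3COC[C@@H]32)cc2c1OC[C@H]2c1ccccc1C` differs from compound 1 by methyl in place of hydrogen on an aromatic carbon, phenyl to 2-methylphenyl. The measured steps are a step that the two limits leave unreadable from compound 1 to compound 2, a step that the two limits leave unreadable from compound 1 to compound 3 and a step that the two limits leave unreadable from compound 2 to compound 3. All three change the group on an amide-type nitrogen, none has a readable size, and none bears directly on this methyl. No step beyond the scatter is therefore expected in this assay. The estimated change is an at least 1.2-fold lower number from compound 1 to compound 4 (0.10 log units; that floor lies within the scatter). Compound 4 is expected at 130 ug/mL, with an estimated range of 50 ug/mL to 200 ug/mL.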

Compound 4, solubility: >= 103 ug/mL
Compound 4: no number, only a limit; the forecaster's own chance of this, stated with the estimate: 50%; the middle value lies beyond the limit too.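

In this assay compound 1 and compound 4 both give only limits, so no step can be read for phenyl to 2-methylphenyl. The compounds shown leave open whether that change shifts the value in this assay at all.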